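A few compounds are considered here, and "the series" means these few. Any claim that something is new, unique, unknown or untested is made for them only; others in the source may bear on it.

In an assay on cell membranes for binding affinity to 2-oxoglutarate receptor 1 (Rattus norvegicus), read by radioligand binding (on this read-out lower numbers stand for stronger inhibition and higher numbers for weaker inhibition), compound 1 `CCCCCNC(=O)[C@H]1O[C@@H](n2cnc3c(N)ncnc32)[C@H](O)[C@@H]1O` gives 12 nM, the lowest of the three numbers shown. Compound 2 `CCCCCCNC(=O)[C@H]1OC(n2cnc3c(N)ncnc32)[C@H](O)[C@@H]1O` gives 19 nM, within the scatter of compound 1, while compound 3 `CCCCCCCCCCCCNC(=O)[C@H]1OC(n2cnc3c(N)ncnc32)[C@H](O)[C@@H]1O` gives 163 nM; the step of an 8.6-fold higher number from compound 2 to compound 3 (0.93 log units; beyond the scatter) shows that lengthening the chain raised the number beyond the scatter. Compound 4 `CC(C)(C)NC(=O)[C@H]1O[C@@H](n2cnc3c(N)ncnc32)[C@H](O)[C@@H]1O` differs from compound 1 by tert-butyl in place of pentyl on an amide-type nitrogen. Among the compounds with values here, no measured step covers this kind of swap of a straight chain for a shorter group; the only step known, from compound 2 to compound 3, concerns chain length alone and guides the estimate only loosely. A modest rise in this assay, a 2.1-fold higher number from compound 1 to compound 4 (0.32 log units; beyond the scatter), is therefore expected, with wide uncertainty. Compound 4 is estimated at 25 nM, between 8 nM and 80 nM.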

Compound 4, inhibition constant: 6850 nM
Beside the measured number, compound 4's estimate is 270-fold (2.44 log units) below it, and the stated range ends below it.
By their numbers in this assay, from the lowest: compounds 1 and 2 (each within the scatter of the next); then compound 3; then compound 4.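

In this assay, the swap of pentyl for tert-butyl on the amide-type nitrogen gives a 570-fold higher number from compound 1 to compound 4 (2.76 log units; beyond the scatter). This is a much bigger change than an 8.6-fold higher number from compound 2 to compound 3 (0.93 log units; beyond the scatter), so this position responds far more to this swap than to the lengthening of a straight chain, although the group entering has 4 heavy atoms against 5 for the group leaving. Nothing measured here explains the size of this rise. The compounds shown leave open whether a straight butyl chain would keep the low number of compound 1, which would help separate the effect of chain length from that of branching.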